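The source may report more compounds than this note shows. Statements on the series, on what has been measured and on what is new or still open speak of the compounds shown alone.

Measured compounds:
Compound 1 `CCC(O)CO[C@H](CC=C(C)C)C1=CC(=O)c2c(O)ccc(O)c2C1=O` gives 28700 nM.
Compound 2 `CCC(CO[C@H](CC=C(C)C)C1=CC(=O)c2c(O)ccc(O)c2C1=O)OC(C)=O` gives 44000 nM.
Compound 3 `CC(C)=CC[C@@H](OCCO)C1=CC(=O)c2c(O)ccc(O)c2C1=O` gives 18600 nM.

These three share one core and differ only in the side chain on the oxygen on a saturated carbon. In a functional assay on HeLa cells (Homo sapiens) for cytotoxicity, read by MTT assay (on this read-out higher numbers stand for weaker inhibition and lower numbers for stronger inhibition), compound 1 lies in the middle of the three values, within the scatter of both neighbours: the step of a 1.5-fold higher number from compound 1 to compound 2 (0.19 log units; within the scatter) and the step of a 1.5-fold lower number from compound 1 to compound 3 (0.19 log units; within the scatter) are each too small to count. Within the data shown here, only the step of a 2.4-fold lower number from compound 2 to compound 3 (0.37 log units; beyond the scatter) reaches beyond the scatter, and modestly so.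

Compound 4 `CCC(C)(O)CC(=O)O[C@H](CC=C(C)C)C1=CC(=O)c2c(O)ccc(O)c2C1=O` is not yet measured. Compared with compound 1 it carries (2-hydroxy-2-methylbutyl)carbonyl in place of 2-hydroxybutyl on an oxygen on a saturated carbon. Among the measured compounds shown here, no measured step reproduces this change, which swaps an ether-linked chain for an ester-linked one. The closest guides are the step from compound 1 to compound 2, where an acetyl replaced a hydroxyl hydrogen, and the step from compound 1 to compound 3, where an ethyl was removed; both stayed within the scatter. Side-chain edits of this kind have therefore moved this assay little, so compound 4 is expected to land near compound 1, with a step of a 1.1-fold lower number from compound 1 to compound 4 (0.06 log units; within the scatter) and an estimated value of 25000 nM, likely between 8000 nM and 80000 nM.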

Compound 4, half-maximal inhibitory concentration: 25200 nM
The estimate for compound 4 lay 1.0-fold (0.00 log units) below the measured number; low and high end bracket the measured number.
By their numbers in this assay, from the lowest: compounds 3, 4, 1 and 2 (each within the scatter of the next, the first and the last beyond it).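

Measured in this assay, the result shows that this oxygen on a saturated carbon can carry an ester-linked chain as well as an ether-linked one: replacing 2-hydroxybutyl with (2-hydroxy-2-methylbutyl)carbonyl gives no change that can be told from scatter (a 1.1-fold lower number from compound 1 to compound 4 (0.06 log units; within the scatter)). Compound 4 also stays within the scatter of the two compounds whose numbers lie furthest apart, with both a 1.4-fold higher number from compound 3 to compound 4 (0.13 log units; within the scatter) and a 1.7-fold lower number from compound 2 to compound 4 (0.24 log units; within the scatter) too small to count, so it cannot be assigned to either end of the one gap that does exceed the scatter (a 2.4-fold lower number from compound 2 to compound 3 (0.37 log units; beyond the scatter)). Nothing available here accounts for why the number moves so little when the link changes.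

Compound 4 alters the link and the chain in one step, so the shown compounds cannot separate the effect of the carbonyl from that of the added methyl on the chain. Every side chain shown is an open chain of carbon and oxygen atoms, which leaves open what an amine, a carboxylic acid, a phenyl ring or a much longer chain would do on this oxygen.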